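The source may report more compounds than this note shows. Statements on the series, on what has been measured and on what is new or still open speak of the compounds shown alone.

Measured compounds in the series:
compound 1 `CCCCN(C)c1cc(C(F)(F)F)ccc1CNC(=O)C(C)c1ccc(NS(C)(=O)=O)c(F)c1` gives 1.2 nM
compound 2 `CC(C(=O)NCc1ccc(C(F)(F)F)cc1N1CCN(C2CCCCC2)CC1)c1ccc(NS(C)(=O)=O)c(F)c1` gives 13.8 nM
compound 3 `CCCCSc1cc(C(F)(F)F)ccc1CNC(=O)C(C)c1ccc(NS(C)(=O)=O)c(F)c1` gives 1.9 nM

All three values come from an assay on CHO cells for antagonist activity at transient receptor potential cation channel subfamily V member 1 (Homo sapiens), read by FLIPR; on this read-out lower numbers stand for stronger inhibition and higher numbers for weaker inhibition. On these numbers compound 1 stands lowest; compound 3 sits nearest to it, a gap within the scatter, and compound 2 lies furthest away, a gap beyond the scatter.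

Compound 4 `CC(C)CCSc1cc(C(F)(F)F)ccc1CNC(=O)C(C)c1ccc(NS(C)(=O)=O)c(F)c1` has not been measured. Relative to compound 1 the change is isopentylsulfanyl in place of butyl(methyl)amino on an aromatic carbon. The step that bears most directly on it is a 1.6-fold higher number from compound 1 to compound 3 (0.20 log units; within the scatter), where a butylsulfanyl group replaced the same butyl(methyl)amino group and the number hardly moved. The other replacement at this carbon, a 12-fold higher number from compound 1 to compound 2 (1.06 log units; beyond the scatter), brought in a ring-bearing group and cost a good deal, but compound 4 carries an open chain of the same heavy-atom count as compound 3 and so follows the first precedent rather than the second. For the measured compounds named here, compound 3 and compound 4 differ only by the branching of the chain on sulfur, and no measured pair speaks to that. The step expected for compound 4 is therefore small, likely an upward drift in the number, at most near the edge of the scatter: a 2.1-fold higher number from compound 1 to compound 4 (0.32 log units; beyond the scatter). Compound 4 is expected to give 2.5 nM, with a range from 1 nM to 6 nM.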

Compound 4, inhibition constant: 1.4 nM
For compound 4 the middle estimate is 1.8-fold (0.25 log units) above the measured one; low and high end bracket the measured number.
By their numbers in this assay, from the lowest: compounds 1, 4 and 3 (each within the scatter of the next); then compound 2.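

In this assay, exchanging butyl(methyl)amino for isopentylsulfanyl on this aromatic carbon gives a 1.2-fold higher number from compound 1 to compound 4 (0.07 log units; within the scatter), so a nitrogen-linked and a sulfur-linked open chain cannot be told apart at this position. For the compounds shown here, the added methyl on the saturated chain of the sulfur-linked group gives a 1.4-fold lower number from compound 3 to compound 4 (0.13 log units; within the scatter), the first measured pair on branching in that chain, and a branched isopentylsulfanyl chain reads the same as the straight butylsulfanyl chain within the scatter. The step away from the ring-bearing group, a 9.9-fold lower number from compound 2 to compound 4 (0.99 log units; beyond the scatter), lies beyond the scatter, which leaves compound 1, compound 3 and compound 4 together as the open-chain members and compound 2 apart from all three.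

Nothing at hand gives a reason why the three open chains read alike or why the 4-cyclohexylpiperazin-1-yl group stands apart. Still open, going by these compounds, is how far this position accepts other groups, such as a much shorter ethylsulfanyl chain, an oxygen-linked butoxy chain, or a chain ending in a primary amine or a carboxylic acid.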